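The compounds below may be only part of what the source reports. "The series", "measured", "known", "first", "only" and "open" are said of these compounds alone.

The measured compounds, in an assay on cell membranes for binding affinity to Adrenergic receptor alpha-1 (Rattus norvegicus), read by radioligand binding; a higher number here means a weaker inhibitor, a lower number a stronger inhibitor: compound 1 `O=C(c1ccco1)N1CCN(c2cnn(CCCN3CCN(c4ccccc4Cl)CC3)c(=O)c2Cl)CC1` gives 3.5 nM; compound 2 `O=C(c1ccco1)N1CCN(c2cnn(CCCCN3CCN(c4ccccc4Cl)CC3)c(=O)c2Cl)CC1` gives 19 nM; compound 3 `COc1ccccc1N1CCN(CCCCCn2ncc(N3CCN(C(=O)c4ccco4)CC3)c(Cl)c2=O)CC1` gives 1.9 nM.

Compound 3 stands lowest of the three numbers; compound 1 lies within the scatter of it, while compound 2 lies beyond it. The unmeasured compound 4 `O=C(c1ccco1)N1CCN(c2cnn(CCCCCN3CCN(c4ccccc4Cl)CC3)c(=O)c2Cl)CC1` differs from compound 3 by chloro in place of methoxy on an aromatic carbon. For the measured compounds named here, no measured pair shows this change on its own, so its size is uncertain. Compounds 1 and 2 already carry the 2-chlorophenyl group, and compound 1 reaches 3.5 nM with it. A step of no more than the scatter, in either direction, is expected: a 2.1-fold higher number from compound 3 to compound 4 (0.32 log units; beyond the scatter). Compound 4 is estimated at 4 nM, between 1.5 nM and 12 nM.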

Compound 4, inhibition constant: 3.6 nM
Estimate against measurement, compound 4: 1.1-fold (0.05 log units) above; the range from low to high includes it.
By their numbers in this assay, from the lowest: compounds 3, 1 and 4 (each within the scatter of the next); then compound 2.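

Chloro in place of methoxy gives a 1.9-fold higher number from compound 3 to compound 4 (0.28 log units; within the scatter) in this assay at this aromatic carbon, ortho to a large group, so here the two groups cannot be told apart. For the compounds shown here, this is the first pair to show the change on its own, with the rest of the structure held fixed. Nothing available accounts for this result.

As far as these compounds go, the 2-methoxyphenyl counterparts of compound 1 and compound 2 remain open, so it is unknown whether the change stays this small elsewhere. Fluoro, methyl or an amine at this position also remain open.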